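A few compounds are considered here, and "the series" means these few. Any claim that something is new, unique, unknown or untested is made for them only; others in the source may bear on it.

Measured compounds:
Compound 1 `CC(=O)C1=C(C)NC(=O)NC1c1ccsc1` — 1%
Compound 2 `CC1=C(C(=O)NC(C)C)C(c2ccsc2)NC(=O)N1` — 1%
Compound 3 `CCSC(=O)C1=C(C)NC(=O)NC1c1ccoc1` — 1%

All three compounds were tested in an assay on membranes from HeLa cells for displacement of a labelled ligand from adenosine receptor A3 (Homo sapiens), read by scintillation counting, with a stated time of 180 min, tested at 1 uM; on this read-out higher numbers stand for more inhibition at the one concentration tested (going by the name of the read-out) and lower numbers for less inhibition. Compound 3 stands level with compounds 1 and 2, within the usual scatter of this kind of measurement, so none of the three can be set apart from the others.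

Among the compounds with values here, only one single-point comparison among the measured compounds exists: from compound 1 to compound 2, where isopropylamino takes the place of methyl on a carbonyl carbon, the result was no change at the digits printed from compound 1 to compound 2 (within the scatter). That change touches a different part of the shared core than the one considered next, so it says little directly about it, but it does show that a change on this core left the read-out where it was.

Compound 4 is `CCSC(=O)C1=C(C)NC(=O)NC1c1ccsc1`. Compared with compound 3, the difference is thiophen-3-yl in place of furan-3-yl on a saturated ring carbon. Compound 1 also carries thiophen-3-yl on a saturated ring carbon and gives 1%, which is the same level as compound 3. Within the data shown here, no measured step shows any movement beyond the scatter in this assay, so the expected step from compound 3 to compound 4 is no change at the digits printed from compound 3 to compound 4 (within the scatter), meaning no change beyond the scatter. Compound 4 is therefore estimated at 1%, with a range from -6% to 9%.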

Compound 4, a percentage reported as inhibition, at one concentration (the size of the read-out at that concentration, not a potency): 2%
For compound 4 the middle estimate is 1 percentage points below the measured one; the range from low to high includes it.
By their numbers in this assay, from the lowest: compounds 1, 2, 3 and 4 (each within the scatter of the next).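

In this assay, thiophen-3-yl in place of furan-3-yl on the saturated ring carbon gives a number 1 percentage points higher from compound 3 to compound 4 (within the scatter), the first direct test of this position, and swapping the oxygen of this five-membered aromatic ring for sulfur leaves the read-out where it was. With thiophen-3-yl held in place, the carbonyl carbon can now be read as well: ethylsulfanyl in place of isopropylamino gives a number 1 percentage points higher from compound 2 to compound 4 (within the scatter), and ethylsulfanyl in place of methyl gives a number 1 percentage points higher from compound 1 to compound 4 (within the scatter), so methyl, isopropylamino and ethylsulfanyl on that carbonyl carbon stand level. No available evidence explains why these changes leave the read-out flat.

All four compounds sit together at the same low level at the one concentration tested, so these results cannot show whether either position has any influence on displacement of the labelled ligand from this receptor. Going by these compounds, it remains open whether a phenyl ring on the saturated ring carbon, or a carboxylic acid or a longer chain on the carbonyl carbon, would move the read-out beyond the scatter.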